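Compound 1 and a hydroxy swap

A few compounds are considered here, and "the series" means these few. Any claim that something is new, unique, unknown or untested is made for them only; others in the source may bear on it.

Compound 1 `COc1ccc(S(=O)(=O)N2CCc3cccc(-c4ccc(F)cc4)c32)cc1` gives 79 nM
Compound 2 `COc1ccc(S(=O)(=O)N2CCc3cccc(-c4c(F)c(F)c(F)c(F)c4F)c32)cc1` gives 1780 nM

In a functional assay on MKN-45 cells (Homo sapiens) for inhibition, with a stated time of 72 h (on this read-out lower numbers stand for stronger inhibition and higher numbers for weaker inhibition), compound 1 holds the lower of the two numbers, and compound 2 lies above it, beyond the scatter. Compound 3 `COc1ccc(S(=O)(=O)N2CCc3cccc(-c4ccc(O)cc4)c32)cc1` carries hydroxy in place of fluoro on an aromatic carbon, so 4-fluorophenyl becomes 4-hydroxyphenyl, para to a large group. Going by the values given here, no measured pair shows this change, so the expectation is loose. What is expected is a modest rise, estimated as a 2.5-fold higher number from compound 1 to compound 3 (0.40 log units; beyond the scatter) in this assay and not a large loss. Compound 3 is estimated at 200 nM (range 40 nM to 900 nM) on this read-out.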

Compound 3, half-maximal inhibitory concentration: 82.6 nM
The estimate for compound 3 lay 2.4-fold (0.38 log units) above the measured number; the measured number falls inside the stated range.
By their numbers in this assay, from the lowest: compounds 1 and 3 (each within the scatter of the next); then compound 2.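

Hydroxy in place of fluoro, para to a large group, gives a 1.0-fold higher number from compound 1 to compound 3 (0.02 log units; within the scatter) in this assay. Going by these compounds alone, the earlier compounds carried only fluoro on this ring, so compound 3 is the first reading of a different group here, and a group with one hydrogen-bond donor and one acceptor stays within the scatter of fluoro. Nothing available explains why the two groups read alike. From the compounds shown here alone, whether an amine or a carboxylic acid at this place would also match compound 1 stays open. So does whether hydroxy would read the same on the other carbons of this ring.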